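The compounds below may be only part of what the source reports. "The series", "measured", "known", "first", "only" and "open" are said of these compounds alone.

Three compounds have been measured in an ADME assay on cells for inhibition of cytochrome P450 11B1, mitochondrial (Homo sapiens), read by HPLC, with a stated time of 60 min; on this read-out higher numbers stand for weaker inhibition and lower numbers for stronger inhibition:

compound 1, `Fc1ccc2nc(-n3ccnn3)n(C3CC3)c2c1`, gives 9070 nM
compound 2, `Fc1ccc2nc(-c3cncs3)n(C3CC3)c2c1`, gives 4520 nM
compound 3, `Fc1ccc2nc(-c3cncnc3)n(C3CC3)c2c1`, gives 5380 nM

Compound 3 stands second highest of these three numbers, and its distance to each neighbour is within the scatter: a 1.2-fold higher number from compound 2 to compound 3 (0.08 log units; within the scatter) and a 1.7-fold lower number from compound 1 to compound 3 (0.23 log units; within the scatter). Compound 4, `Fc1ccc2nc(-c3ccnnc3)n(C3CC3)c2c1`, differs from compound 3 by pyridazin-4-yl in place of pyrimidin-5-yl on an aromatic carbon. The measured steps that bear on this are the three swaps of one small aromatic ring for another at that same place: a 2.0-fold lower number from compound 1 to compound 2 (0.30 log units; within the scatter), a 1.7-fold lower number from compound 1 to compound 3 (0.23 log units; within the scatter) and a 1.2-fold higher number from compound 2 to compound 3 (0.08 log units; within the scatter), none of them beyond the scatter. The same is therefore expected in this assay, a step of a 1.0-fold lower number from compound 3 to compound 4 (0.01 log units; within the scatter). Compound 4 is estimated at 5200 nM, with a range from 2200 nM to 12500 nM.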

Compound 4, half-maximal inhibitory concentration: > 10000 nM
Compound 4 was reported as a limit; the forecaster's own chance of this, stated with the estimate: 5%; middle value at least 1.9-fold (0.28 log units) from the limit.
By their numbers in this assay, from the lowest: compounds 2, 3 and 1 (each within the scatter of the next). At a limit, above all of these: compound 4.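

In this assay compound 4 is reported only as a limit, not as a number: the limit of > 10000 nM in this assay, at which 1 of the 4 values shown sits. For the compounds shown here, this position does respond to the choice of ring, since pyridazin-4-yl in place of 1,3-thiazol-5-yl gives an at least 2.2-fold higher number from compound 2 to compound 4 (0.34 log units; beyond the scatter), the first step beyond the scatter. The other two floors, an at least 1.8-fold higher number from compound 3 to compound 4 (0.26 log units; that floor lies within the scatter) and an at least 1.1-fold higher number from compound 1 to compound 4 (0.04 log units; that floor lies within the scatter), stay within the scatter, so those changes have no fixed size, even for two rings with the same atoms joined differently. As far as these compounds go, how far compound 4 lies past its limit remains open, as does whether an amine or a carboxylic acid at this place would lower the number.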